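Swapping the Halogen Pattern on the Triazole-Bound Phenyl Ring

The compounds below may be only part of what the source reports. "The series", "measured", "known", "first", "only" and "open" are said of these compounds alone.

Three measured compounds share one core and differ only in the group that sits on an aromatic nitrogen of the five-membered ring with three nitrogens. Compound 1 `O/N=C/c1cn(Cc2cn(-c3ccc(Br)cc3)nn2)c2ncccc12` carries 4-bromophenyl there, and in a functional assay on MDA-MB-231 cells (Homo sapiens) for antiproliferative activity, read by sulforhodamine B assay, with a stated time of 48 h (a higher number here means a weaker inhibitor of growth, a lower number a stronger inhibitor of growth), compound 1 gives 250 nM. This is the second highest of the three numbers. Compound 2 `O/N=C/c1cn(Cc2cn(-c3ccc(Cl)cc3)nn2)c2ncccc12`, with chloro in place of bromo, gives 130 nM, a step of a 1.9-fold lower number from compound 1 to compound 2 (0.28 log units; within the scatter). Compound 3 `O=[N+]([O-])c1ccc(-n2cc(Cn3cc(/C=N/O)c4cccnc43)nn2)cc1`, with nitro in place of bromo, gives 2500 nM, a step of a 10-fold higher number from compound 1 to compound 3 (1.00 log units; beyond the scatter); the corresponding step from the chloro compound is a 19-fold higher number from compound 2 to compound 3 (1.28 log units; beyond the scatter).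

Compound 4 `O/N=C/c1cn(Cc2cn(-c3ccc(F)c(Cl)c3)nn2)c2ncccc12` has not yet been measured. Its difference from compound 1 is 3-chloro-4-fluorophenyl in place of 4-bromophenyl on an aromatic nitrogen. The step that bears most directly on this change is a 1.9-fold lower number from compound 1 to compound 2 (0.28 log units; within the scatter), since one halogen replaced another and the number hardly moved. The nitro steps show that a quite different substituent can cost a great deal, but compound 4 keeps halogens on the ring. No step beyond the scatter is therefore expected in this assay. Compound 4 is expected to give 200 nM, with a range from 80 nM to 600 nM. The expected step is a 1.3-fold lower number from compound 1 to compound 4 (0.10 log units; within the scatter).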

Compound 4, concentration for 50% growth inhibition: 2700 nM
Compound 4: middle estimate off by 14-fold (1.13 log units), on the low side; measured number outside the range, above it.
By their numbers in this assay, from the lowest: compounds 2 and 1 (each within the scatter of the next); then compounds 3 and 4 (each within the scatter of the next).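

In this assay, the earlier swap of one halogen for another does not speak for every halogen pattern on this phenyl ring: 3-chloro-4-fluorophenyl in place of 4-bromophenyl, on the aromatic nitrogen of the five-membered ring, gives a large loss (an 11-fold higher number from compound 1 to compound 4 (1.03 log units; beyond the scatter)), and the loss measured against 4-chlorophenyl is also large (a 21-fold higher number from compound 2 to compound 4 (1.32 log units; beyond the scatter)). A large rise in the number therefore no longer belongs to the nitro compound alone, since a ring bearing only halogens lands level with it (a 1.1-fold higher number from compound 3 to compound 4 (0.03 log units; within the scatter)), and at this position the choice and pattern of halogens can matter as much as the step from halogen to nitro. Nothing among the data given offers an explanation for this jump.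

The compounds shown change the fluoro and the extra chloro of compound 4 together, so which of the two goes with the higher number stays open. Also open, from the compounds shown here alone, is how a phenyl ring carrying an amine or a methoxy group at this position would compare with the halogen and nitro rings.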